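From 4-Methoxyphenyl to 4-Fluorophenyl: An Open Question

The compounds below may be only part of what the source reports. "The series", "measured", "known", "first", "only" and "open" are said of these compounds alone.

In a functional assay on A549 cells (Homo sapiens) for antiproliferative activity, read by MTT assay, with a stated time of 72 h (on this read-out higher numbers stand for weaker inhibition and lower numbers for stronger inhibition), compound 1 `COc1cc(-n2cnc3ccc(-c4cc(F)ccc4F)cc32)cc(OC)c1OC` gives 7940 nM. Compound 2 `COc1ccc(-c2ccc3ncn(-c4cc(OC)c(OC)c(OC)c4)c3c2)cc1` gives > 10000 nM, which is a limit of the assay and not a number. Compound 2 therefore stands at the limit of > 10000 nM in this assay, at which 1 of the 2 values shown sits.

Compound 3 `COc1cc(-n2cnc3ccc(-c4ccc(F)cc4)cc32)cc(OC)c1OC` follows from compound 2 by placing fluoro in place of methoxy on an aromatic carbon, para to a large group (fluoro in place of methoxy on an aromatic carbon). Going by the values given here, one measured step bears on this change: an at least 1.2-fold higher number from compound 1 to compound 2 (0.10 log units; that floor lies within the scatter), with 4-methoxyphenyl in place of 2,5-difluorophenyl. Its floor lies within the scatter, so it gives no firm size or direction. Compound 3 keeps fluoro on its phenyl group, as does compound 1 at 7940 nM, so a number near that value seems reasonable.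

The expected change is small, an at least 1.2-fold lower number from compound 2 to compound 3 (0.09 log units; that floor lies within the scatter), towards stronger inhibition if it shows at all.

Compound 3 is estimated at 8000 nM, with an expected range of 2500 nM to 20000 nM.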

Compound 3, half-maximal inhibitory concentration: 6740 nM
Compound 3: the middle estimate sits 1.2-fold (0.07 log units) above what was measured; low and high end bracket the measured number.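

Fluoro in place of methoxy on this aromatic carbon gives an at least 1.4-fold lower number from compound 2 to compound 3 (0.17 log units; that floor lies within the scatter), so the change may favour stronger inhibition, but its true size remains unfixed. The comparison of the two fluorinated compounds, with 4-fluorophenyl in place of 2,5-difluorophenyl, gives a 1.2-fold lower number from compound 1 to compound 3 (0.07 log units; within the scatter), so compound 1 and compound 3 cannot be told apart in this assay. Compound 2 remains a limit of the assay and not a number: the limit of > 10000 nM in this assay, at which 1 of the 3 values shown sits.

From the compounds shown here alone, the actual distance between the 4-methoxyphenyl and 4-fluorophenyl compounds therefore stays open. Also open, going by these compounds, is whether an amine, a carboxylic acid or a longer chain on this aromatic carbon would move the number beyond the scatter.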